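The source may hold more compounds than are shown below. What is called first, only, known or untested is meant among the compounds shown, and "the series" means these compounds.

Compound 1 `COc1ccc(-n2ncnc2-c2cc(OC)c(OC)c(OC)c2)cc1`: 93 nM
Compound 2 `COc1cc(-n2ncnc2-c2ccc(OC(F)(F)F)cc2)cc(OC)c1OC`: > 10000 nM
Compound 3 `COc1cccc(-c2ncnn2-c2cc(OC)c(OC)c(OC)c2)c1`: > 10000 nM

Of the compounds shown here, three built on a shared core have been measured in a functional assay on Jurkat cells (Homo sapiens) for antiproliferative activity, read by MTT assay, with a stated time of 72 h; a lower number here means a stronger inhibitor, a higher number a weaker inhibitor. For the measured compounds named here, compound 1 gives 93 nM, the only number among the three. For compound 2 the result is a limit of the assay, > 10000 nM. For compound 3 the result is likewise a limit, > 10000 nM. Going by the values given here, compound 1 therefore stands alone as the one measured compound with an actual number, while the other two sit at the limit of > 10000 nM in this assay, at which 2 of the 3 values shown sit.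

Compound 4 `COc1cc(-c2ncnn2-c2ccc(Cl)cc2)cc(OC)c1OC` has not yet been measured. It differs from compound 1 in one place: chloro in place of methoxy on an aromatic carbon. Among the compounds with values here, with no measured step of this kind among the three compounds, the size of the change can only be estimated. Compound 4 is expected to remain an inhibitor but somewhat weaker than compound 1. For compound 4 the estimated step is a 4.3-fold higher number from compound 1 to compound 4 (0.63 log units; beyond the scatter). Compound 4 is thus estimated at 400 nM, within a range from 100 nM to 3000 nM.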

Compound 4, half-maximal inhibitory concentration: > 10000 nM
Compound 4 was reported as a limit; the forecaster's own chance of this, stated with the estimate: 15%; middle value at least 25-fold (1.39 log units) from the limit.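

For the compounds shown here, the first step that can be read shows that this position is not tolerant of change: in this assay, chloro in place of methoxy on an aromatic carbon, para to a large group, gives an at least 100-fold higher number from compound 1 to compound 4 (2.03 log units; beyond the scatter). The swap of 4-methoxyphenyl to 4-chlorophenyl is a single change, so among the compounds shown, this methoxy is tied directly to compound 1 keeping a measurable number. The size of the step is only a floor, since the result for compound 4 is itself a limit of the assay, and it joins the other compounds there: the limit of > 10000 nM in this assay, at which 3 of the 4 values shown sit.

On these data alone, whether any replacement of the methoxy would fare the same, or whether a hydroxyl, a methyl or an amine at this place would keep a measurable number, stays open. The compounds at the limit also cannot be ranked against one another.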